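Moving a branch on the chain of compound 3

The source may hold more compounds than are shown below. What is called first, only, known or untested is meant among the compounds shown, and "the series" means these compounds.

Measured in a functional assay on A549 cells (Homo sapiens) for inhibition, read by MTT assay, with a stated time of 72 h; on this read-out lower numbers stand for stronger inhibition and higher numbers for weaker inhibition:
- compound 1 `CCC/C=C\C(=O)Nc1cc(Nc2nc3c(c(-c4cn(C)c5ccc(F)cc45)n2)CSCC3)c(OC)cc1N(C)CCN(C)C`: 5190 nM
- compound 2 `C/C=C\C(=O)Nc1cc(Nc2nc3c(c(-c4cn(C)c5ccccc45)n2)CSCC3)c(OC)cc1N(C)CCN(C)C`: 6860 nM
- compound 3 `COc1cc(N(C)CCN(C)C)c(NC(=O)/C=C\C(C)C)cc1Nc1nc2c(c(-c3cn(C)c4ccccc34)n1)CSCC2`: 788 nM

Compound 3 has the lowest number of the three, and both others lie beyond the scatter from it. Still unmeasured is compound 4 `CCC/C=C\C(=O)Nc1cc(Nc2nc3c(c(-c4cn(C)c5ccccc45)n2)CSCC3)c(OC)cc1N(C)CCN(C)C`, which keeps the same atoms but joins them differently: propyl in place of isopropyl on a double-bonded chain carbon bound to a double-bonded chain carbon. The branched isopropyl gives way to straight propyl, on a double-bonded chain carbon bound to a double-bonded chain carbon.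

Among the measured compounds shown here, one measured step concerns this place: an 8.7-fold lower number from compound 2 to compound 3 (0.94 log units; beyond the scatter). It shows that a change here can shift the number well beyond the scatter. Compound 1 gives 5190 nM and already carries propyl at this place, along with a fluorine that compound 4 lacks. What that fluorine contributes has not been measured alone, so this is only a rough guide.

A move to a higher number in this assay, meaning weaker inhibition, is therefore expected, with an estimated size of a 3.8-fold higher number from compound 3 to compound 4 (0.58 log units; beyond the scatter). Compound 4 is expected at 3000 nM, within an estimated range of 1000 nM to 8000 nM.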

Compound 4, half-maximal inhibitory concentration: 571 nM
Compound 4: middle estimate off by 5.3-fold (0.72 log units), on the high side; measured number below the stated range.
By their numbers in this assay, from the lowest: compounds 4 and 3 (each within the scatter of the next); then compounds 1 and 2 (each within the scatter of the next).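

In this assay, straightening the chain leaves no measurable difference: a 1.4-fold lower number from compound 3 to compound 4 (0.14 log units; within the scatter), so isopropyl and propyl cannot be told apart at this place. The size of the group here still matters, as a 12-fold lower number from compound 2 to compound 4 (1.08 log units; beyond the scatter) shows for ethyl in place of hydrogen on a saturated chain carbon bound to a double-bonded chain carbon, and the higher number of compound 1 now traces to the fluoro group elsewhere on the molecule, with a 9.1-fold lower number from compound 1 to compound 4 (0.96 log units; beyond the scatter). No measurement on hand explains any of these shifts.

Open, going by these compounds, is whether a longer chain, a cyclopropyl ring or an amine at this place would keep the number in the same range as compound 3 and compound 4. Also open, on these data alone, is whether the fluoro step would be of similar size on the isopropyl chain of compound 3.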